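Arylurea series: configuration swap at the benzylic centre

The source may hold more compounds than are shown below. What is called first, only, known or untested is meant among the compounds shown, and "the series" means these compounds.

Measured so far:
- compound 1 `CCc1ccc(NC(=O)N[C@@H](C)c2ccccc2)cc1` — 95%
- compound 2 `CCCCCc1ccc(NC(=O)N[C@H](C)c2ccccc2)cc1` — 101%

Both compounds were run in an ADME assay on the whole organism with Oryza sativa as the target, tested at 1 uM; on this read-out higher numbers stand for a weaker effect at the one concentration tested and lower numbers for a stronger effect. In this assay compound 1 gives 95% and compound 2 gives 101%. Among the measured compounds shown here, of the two numbers compound 2 shows the higher one, but the gap to compound 1 lies within the scatter, so the two cannot be told apart on this read-out; no step between them has been worked out, and their chains and drawn configurations both differ.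

The next compound, compound 3 `CCCCCc1ccc(NC(=O)N[C@@H](C)c2ccccc2)cc1`, is still to be measured in this assay. Relative to compound 2 the change is the two compounds have the same atoms and bonds and differ only in configuration as drawn: 1 of 1 stereo elements differ; a stereocentre at a saturated chain carbon is drawn R in compound 2 and S in compound 3.

For the measured compounds named here, with no measured step and both measured compounds sitting at essentially full activity, nothing points to a move beyond the scatter. The expected step from compound 2 to compound 3 in this assay is a number 4 percentage points lower from compound 2 to compound 3 (within the scatter), that is, none beyond the scatter. Compound 3 is therefore estimated at 97% in this assay, with a range from 85% to 110%.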

Compound 3, a percentage reported as activity, at one concentration (the size of the read-out at that concentration, not a potency): 98%
Estimate against measurement, compound 3: 1 percentage points below; low and high end bracket the measured number.
By their numbers in this assay, from the lowest: compounds 1, 3 and 2 (each within the scatter of the next).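

In this assay, the stereocentre at the saturated chain carbon can now be read on its own: inverting it from R to S gives a number 3 percentage points lower from compound 2 to compound 3 (within the scatter), so this change at this position shows no effect beyond the scatter. This pair speaks to configuration alone, because nothing else separates the two structures: the fact that compounds 2 and 3 differ only in the configuration as drawn

Among the compounds shown here, the chain can also be read for the first time at a fixed drawn configuration, since propyl in place of hydrogen on a saturated chain carbon, two bonds along the chain from an aromatic carbon, gives a number 3 percentage points higher from compound 1 to compound 3 (within the scatter), again with no change beyond the scatter.

Neither step shows whether configuration or chain length would matter in a compound whose number differs beyond the scatter from those of this set, as all three compounds lie within the scatter of each other at the one concentration tested. Going by these compounds, it also remains open whether a longer chain, or an amine or a carboxylic acid in place of the propyl, would move the number in this assay beyond the scatter.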